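The compounds below may be only part of what the source reports. "The series", "measured", "known", "first", "only" and "open" are said of these compounds alone.

Compound 2 `N#CC1=C(N)N(c2ccc(S(N)(=O)=O)cc2)C2=C(CCCC2)C1/C=C/c1ccccc1` gives 70% in a functional assay on Ehrlich cells (Mus musculus) for cytotoxicity, read by trypan blue exclusion, with a stated time of 2 h, tested at 25 ug/mL (a higher number here means a stronger effect of the compound at the concentration tested, a lower number a weaker effect), the highest of the two numbers in hand. Going by the values given here, its nearest neighbour is compound 1 `N#CC1=C(N)N(c2ccc(S(N)(=O)=O)cc2)C2=C(CCCC2)C1c1ccccc1`, which in this assay gives 10%; the single step between them, a number 60 percentage points higher from compound 1 to compound 2 (beyond the scatter), came with 2-phenylethenyl in place of phenyl on a saturated ring carbon. Compound 3 `COc1ccc(C2C(C#N)=C(N)N(c3ccc(S(N)(=O)=O)cc3)C3=C2CCCC3)cc1` is the next candidate; it differs from compound 2 by 4-methoxyphenyl in place of 2-phenylethenyl on a saturated ring carbon. Among the compounds with values here, this change largely undoes the one measured step in the set, removing the 2-phenylethenyl that accompanied the large rise and returning a six-membered aromatic ring of carbon only to the same place, so a fall back toward the value of compound 1 is the natural expectation, while no measured step bears on 4-methoxyphenyl itself. The expected step is a number 50 percentage points lower from compound 2 to compound 3 (beyond the scatter), a fall. Compound 3 is therefore estimated to give 20%, with a range from 5% to 45%.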

Compound 3, a percentage reported as activity, at one concentration (the size of the read-out at that concentration, not a potency): 90%
Compound 3: the middle estimate sits 70 percentage points below what was measured, and the stated range ends below it.
By their numbers in this assay, from the lowest: compound 1; then compound 2; then compound 3.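

In this assay there is a number 20 percentage points higher from compound 2 to compound 3 (beyond the scatter) and this shows that the saturated ring carbon does not need 2-phenylethenyl for a high reading, since 4-methoxyphenyl gives the strongest effect of the three compounds. The same position also responds strongly to a small change on its aromatic ring: there is a number 80 percentage points higher from compound 1 to compound 3 (beyond the scatter) with methoxy in place of hydrogen on an aromatic carbon as the only difference. Nothing available explains this rise.

From the compounds shown here alone, it remains open whether the gain is specific to methoxy or would also appear with a hydroxyl group, a chlorine atom or a dimethylamino group on the same aromatic ring. Also open, going by these compounds, is how a longer alkoxy chain, such as butoxy, would read in this assay at this place.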